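Chloro for Fluoro on the Aryl Ring of Compound 2

This account rests on a few compounds, and the source may have more. Where it says the series, first, only, none or still open, it means among the compounds named here.

In a functional assay on the whole organism (strain Wistar) for inhibition, with Rattus norvegicus as the target, read by paw edema, with stated times of 30 min and 60 min, at a dose of 50 mg/kg by the oral route (on this read-out higher numbers stand for more inhibition at the one dose given (going by the name of the read-out) and lower numbers for less inhibition), compound 2 `O=[N+]([O-])c1ccc(N2N=C(c3ccc(F)cc3)CC2c2cn(-c3ccccc3)nc2-c2ccc(Cl)c(Cl)c2)cc1` gives 60.3%. Compound 1 `CC(=O)N1N=C(c2ccc(Cl)cc2)CC1c1cn(-c2ccccc2)nc1-c1ccc(Cl)c(Cl)c1` in this assay gives 57.3%, so compound 2 stands alongside compound 1 within the scatter, with no real gap between the two. Compound 3 `O=[N+]([O-])c1ccc(N2N=C(c3ccc(Cl)cc3)CC2c2cn(-c3ccccc3)nc2-c2ccc(Cl)c(Cl)c2)cc1` has not yet been measured. It differs from compound 2 by chloro in place of fluoro on an aromatic carbon. Within the data shown here, no measured pair shows such an exchange, so the expected step of a number 1.7 percentage points higher from compound 2 to compound 3 (within the scatter) is none beyond the scatter. Compound 3 is therefore expected to give 62%, within a range from 50% to 74%.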

Compound 3, a percentage reported as inhibition, in the whole organism at one dose (the size of the read-out at that dose, not a potency): 57.3%
Beside the measured number, compound 3's estimate is 4.7 percentage points above it; the range from low to high includes it.
By their numbers in this assay, from the lowest: compounds 1, 3 and 2 (each within the scatter of the next).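

In this assay, going from 4-fluorophenyl to 4-chlorophenyl gives a number 3 percentage points lower from compound 2 to compound 3 (within the scatter), so at this position the exchange of fluoro for chloro separates the two compounds by no more than the scatter. Among these compounds, with 4-chlorophenyl held in place, 4-nitrophenyl in place of acetyl on the amine nitrogen in a ring gives no change at the digits printed from compound 1 to compound 3 (within the scatter), which shows that exchange on its own for the first time. No available evidence bears on either result.

Open, going by these compounds, is whether a methoxy group or an amine at the aromatic position, or a carboxylic acid on the aryl group at the ring nitrogen, would shift the inhibition beyond the scatter.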